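Dropping the Methyl from the Sulfonyl Ring

This account rests on a few compounds, and the source may have more. Where it says the series, first, only, none or still open, it means among the compounds named here.

Measured so far:
compound 1 `Cc1ccc(S(=O)(=O)NCc2ccc(CNC(=O)c3ccc([N+](=O)[O-])cc3)cc2)cc1`: 10 nM
compound 2 `COc1cccc(C(=O)NCc2ccc(CNS(=O)(=O)c3ccc(C)cc3)cc2)c1`: 10 nM

In an assay on MDA-MB-231 cells for binding affinity to C-X-C chemokine receptor type 4 (Homo sapiens), read by immunofluorescence and microscopy, with stated times of 10 min and 30 min (on this read-out higher numbers stand for an effect only at larger amounts of compound and lower numbers for an effect already at smaller amounts), compound 1 stands level with compound 2; compound 1 gives 10 nM and compound 2 gives 10 nM. Among the compounds with values here, the single measured step, no change at the digits printed from compound 1 to compound 2 (within the scatter), swapped the aryl on the carbonyl carbon and stayed within the scatter. Compound 3 `O=C(NCc1ccc(CNS(=O)(=O)c2ccccc2)cc1)c1ccc([N+](=O)[O-])cc1` alters a different part of the molecule: hydrogen in place of methyl on an aromatic carbon, which reads as (4-methylphenyl)sulfonyl to phenylsulfonyl. Within the data shown here, no measured step touches this sulfonyl group, so the one known step bears on it only loosely. Compound 3 is expected near 10 nM, from 4 nM to 25 nM. The step of no change at the digits printed from compound 1 to compound 3 (within the scatter) is therefore estimated to stay within the scatter.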

Compound 3, effective concentration (reported as EC, without a stated level of effect): 100 nM
Estimate against measurement, compound 3: 10-fold (1.00 log units) below; measured number outside the range, above it.
By their numbers in this assay, from the lowest: compounds 1 and 2 (each within the scatter of the next); then compound 3.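

This position responds where the earlier swap did not. In this assay, removing one methyl gives a 10-fold higher number from compound 1 to compound 3 (1.00 log units; beyond the scatter), so the phenylsulfonyl compound needs a larger amount for the same read-out, although the change at the carbonyl end gave no change at the digits printed from compound 1 to compound 2 (within the scatter). Nothing available explains the effect of this methyl. Still open, going by these compounds, is how a chlorine atom or an ethyl group at this same ring carbon would read. Also open, on these data alone, is whether removing the methyl from compound 2 would produce a similar step.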